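The source may hold more compounds than are shown below. What is called first, only, known or untested is meant among the compounds shown, and "the series" means these compounds.

Going by the values given here, compound 2 `CC1(C)[C@@H](Nc2cc(NCc3cnccc3C(F)(F)F)ncc2C#N)C[C@H]1C(N)=O` gives 4500 nM in an assay on isolated protein for inhibition of protein kinase C delta type (Homo sapiens), read by TR-FRET, with a stated time of 2 h (a higher number here means a weaker inhibitor, a lower number a stronger inhibitor), the higher of the two numbers known, though its step from compound 1 `CC1(C)C[C@@H](Nc2cc(NCc3cnccc3C(F)(F)F)ncc2C#N)CC[C@H]1O`, which gives 2400 nM, is small: a 1.9-fold higher number from compound 1 to compound 2 (0.27 log units; within the scatter). Compound 3 `CC1(C)[C@@H](Nc2cc(NCc3cnccc3C(F)(F)F)ncc2C#N)C[C@@H]1C(N)=O` keeps every atom and bond of compound 2; (the two compounds have the same atoms and bonds and differ only in configuration as drawn: 1 of 2 stereo elements differ; a stereocentre at a saturated ring carbon is drawn R in compound 2 and S in compound 3). Among the compounds with values here, no measured step changes configuration alone, so the single step from compound 1 to compound 2 bears only loosely on this change, and nothing in the known numbers points in either direction. The step of a 1.1-fold lower number from compound 2 to compound 3 (0.05 log units; within the scatter) is therefore expected to stay within the scatter. Compound 3 is estimated at 4000 nM, in a range from 1000 nM to 16000 nM.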

Compound 3, half-maximal inhibitory concentration: > 10000 nM
Compound 3: a limit, no number; the forecaster's own chance of this, stated with the estimate: 10%; middle value at least 2.5-fold (0.39 log units) from the limit.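

In this assay compound 3 gives > 10000 nM, which is a limit and not a number. Drawing the saturated ring carbon S rather than R gives an at least 2.2-fold higher number from compound 2 to compound 3 (0.34 log units; beyond the scatter), so the reading depends on configuration at this position, the only thing that changes: the fact that compounds 2 and 3 differ only in the configuration as drawn. The replacement of 4-hydroxy-3,3-dimethylcyclohexyl by 3-carbamoyl-2,2-dimethylcyclobutyl, within the scatter in the R form, goes beyond it in the S form: an at least 4.1-fold higher number from compound 1 to compound 3 (0.61 log units; beyond the scatter).

From the compounds shown here alone, the true size of the configuration step stays open: the limit of > 10000 nM in this assay, at which 1 of the 3 values shown sits. Also open, going by these compounds, is whether a carboxylic acid or an aminomethyl group in place of the carbamoyl would show the same dependence on configuration.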